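This account rests on a few compounds, and the source may have more. Where it says the series, first, only, none or still open, it means among the compounds named here.

Measured so far in a functional assay on cells for inhibition, with Murine T-cell line (Mus musculus) as the target; on this read-out lower numbers stand for stronger inhibition and higher numbers for weaker inhibition:
compound 1 `CC[C@@H]1/C=C(\C)C[C@H](C)C[C@H](OC)[C@H]2O[C@@](O)(C(=O)C(=O)N3CCCC[C@H]3C(=O)O[C@H](/C(C)=C/[C@@H]3CC[C@@H](O)[C@H](Oc4ccc(O)cc4)C3)[C@H](C)[C@@H](O)CC1=O)[C@H](C)C[C@@H]2OC` — 0.9 nM
compound 2 `CC[C@@H]1/C=C(\C)C[C@H](C)C[C@H](OC)[C@H]2O[C@@](O)(C(=O)C(=O)N3CCCC[C@H]3C(=O)O[C@H](/C(C)=C/[C@@H]3CC[C@@H](Oc4ccc(O)cc4)[C@H](OC)C3)[C@H](C)[C@@H](O)CC1=O)[C@H](C)C[C@@H]2OC` — 0.8 nM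
compound 3 `CC[C@@H]1/C=C(\C)C[C@H](C)C[C@H](OC)[C@H]2O[C@@](O)(C(=O)C(=O)N3CCCC[C@H]3C(=O)O[C@H](/C(C)=C/[C@@H]3CC[C@@H](Oc4cccc(O)c4)[C@H](OC)C3)[C@H](C)[C@@H](O)CC1=O)[C@H](C)C[C@@H]2OC` — 1.7 nM

On these numbers compound 1 holds the second highest of the three; compound 2 sits within the scatter of it, and compound 3 also lies within the scatter of compound 1. Going by the values given here, the only step on record, a 2.1-fold higher number from compound 2 to compound 3 (0.33 log units; beyond the scatter), concerns 3-hydroxyphenyl in place of 4-hydroxyphenyl and is modest.

Compound 4 `CC[C@@H]1/C=C(\C)C[C@H](C)C[C@H](OC)[C@H]2O[C@@](O)(C(=O)C(=O)N3CCCC[C@H]3C(=O)O[C@H](/C(C)=C/[C@@H]3CC[C@@H](O)[C@H](Oc4ccc(OC)cc4)C3)[C@H](C)[C@@H](O)CC1=O)[C@H](C)C[C@@H]2OC` differs from compound 1 by methyl in place of hydrogen on an oxygen on an aromatic ring. Among the compounds with values here, no measured pair covers hydroxy to methoxy on this ring, so the step of a 2.1-fold higher number from compound 2 to compound 3 (0.33 log units; beyond the scatter) bears only loosely. The expectation for compound 4 in this assay is therefore no step beyond the scatter, a 1.3-fold higher number from compound 1 to compound 4 (0.12 log units; within the scatter), with the estimate 1.2 nM and range 0.5 nM to 3 nM.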

Compound 4, half-maximal inhibitory concentration: 0.9 nM
For compound 4 the middle estimate is 1.3-fold (0.12 log units) above the measured one, and the stated range covers the measured number.
By their numbers in this assay, from the lowest: compounds 2, 1, 4 and 3 (each within the scatter of the next, the first and the last beyond it).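

Methyl in place of hydrogen on the oxygen of the 4-hydroxyphenoxy group gives no change at the digits printed from compound 1 to compound 4 (within the scatter) in this assay. Going by these compounds alone, the only earlier step, a 2.1-fold higher number from compound 2 to compound 3 (0.33 log units; beyond the scatter), moved the hydroxy around the ring and left the group itself unchanged. Within the data shown here, this is the first reading on that group, and here the free hydroxy hydrogen is not required to hold the number.

On these data alone, whether a longer chain on this oxygen, or an amine or a carboxylic acid in place of the hydroxy, holds the number stays open. No supporting measurement bears on this result.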